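A tert-butyl group in place of nitro on a shared core

The source may report more compounds than this note shows. Statements on the series, on what has been measured and on what is new or still open speak of the compounds shown alone.

The series shares one core, shown for compound 1 as `Cc1ccc(Cn2cc(COc3ccc4c(=O)ccoc4c3)nn2)cc1`, which carries a methyl. In a functional assay on QGY7701 cells (Homo sapiens) for cytotoxicity, read by MTT assay, with a stated time of 48 h (a lower number here means a stronger inhibitor, a higher number a weaker inhibitor), compound 1 gives 68500 nM. Compound 2, `N#Cc1ccc(Cn2cc(COc3ccc4c(=O)ccoc4c3)nn2)cc1`, carries a cyano in place of methyl on an aromatic carbon; in this assay compound 2 reaches only the limit > 100000 nM, not a number. Compound 3, `O=c1ccoc2cc(OCc3cn(Cc4ccc([N+](=O)[O-])cc4)nn3)ccc12`, carries a nitro in place of methyl on an aromatic carbon; in this assay compound 3 likewise sits at the limit > 100000 nM. Compound 3 thus stands at the weak end of what is shown, at the limit of > 100000 nM in this assay, at which 2 of the 3 values shown sit. The measured steps of an at least 1.4-fold higher number from compound 1 to compound 2 (0.16 log units; that floor lies within the scatter) and an at least 1.4-fold higher number from compound 1 to compound 3 (0.16 log units; that floor lies within the scatter) only set floors, and a step that the two limits leave unreadable from compound 2 to compound 3 is all that the two limits allow. Compound 4, `CC(C)(C)c1ccc(Cn2cc(COc3ccc4c(=O)ccoc4c3)nn2)cc1`, differs from compound 3 by tert-butyl in place of nitro on an aromatic carbon. The nearest point of reference is compound 1 with its methyl and its value of 68500 nM, so compound 4 is expected to move back toward that range. Compound 4 is therefore estimated at 70000 nM, between 30000 nM and 150000 nM. The expected step of an at least 1.4-fold lower number from compound 3 to compound 4 (0.15 log units; that floor lies within the scatter) is modest at best.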

Compound 4, half-maximal inhibitory concentration: > 100000 nM
Compound 4 ended at the assay's limit (the forecaster's own chance of this, stated with the estimate: 35%); middle value at least 1.4-fold (0.15 log units) away from the limit.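

With tert-butyl on the aromatic carbon para to a large group, compound 4 joins compound 2 and compound 3 at a limit of this assay rather than at a number: the limit of > 100000 nM in this assay, at which 3 of the 4 values shown sit. Tert-butyl has only carbon atoms, unlike nitro and cyano, yet it also gives no number, so among the groups shown at this position only the methyl of compound 1 does. Among the compounds shown here, the one readable step is an at least 1.4-fold higher number from compound 1 to compound 4 (0.16 log units; that floor lies within the scatter), while the steps to compound 4 from compound 2 and from compound 3 cannot be read.

As far as these compounds go, how far compound 2, compound 3 and compound 4 lie past the limit stays open. For the compounds shown here, also open is whether an amine, a carboxylic acid or a chlorine on this aromatic carbon would give a number in this assay, and how that number would compare with the one for compound 1.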